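Deacetylation at the ring oxygen: compound 1 toward compound 3

The source may report more compounds than this note shows. Statements on the series, on what has been measured and on what is new or still open speak of the compounds shown alone.

Measured so far:
- compound 1 `COc1ccc(C(=O)O[C@H]2CC(C)=C[C@H](OC(C)=O)[C@@]3(C)[C@@H](OC(C)=O)C[C@@](O)(C(C)C)[C@H]23)cc1` — 23300 nM
- compound 2 `C/C=C(/C)C(=O)O[C@H]1CC(C)=C[C@@H](OC(=O)/C(C)=C\C)[C@@]2(C)CC[C@@](O)(C(C)C)[C@H]12` — 2800 nM

Two members of this series have been measured in a functional assay on A549 cells (Homo sapiens) for cytotoxicity, read by MTT assay, with a stated time of 72 h; a higher number here means a weaker inhibitor, a lower number a stronger inhibitor. For the measured compounds named here, compound 1 gives 23300 nM, the highest number of the two; compound 2, the only other compound, gives 2800 nM, and the gap between them lies beyond the usual scatter of repeated measurements. Going by the values given here, the two differ at several places at once, so no single structural step between them can be read off.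

Compound 3 `COc1ccc(C(=O)O[C@H]2CC(C)=C[C@H](O)[C@@]3(C)[C@@H](OC(C)=O)C[C@@](O)(C(C)C)[C@H]23)cc1` differs from compound 1 at one place only: hydrogen in place of acetyl on an oxygen on a saturated carbon. Among the compounds with values here, no measured pair carries the same change, so the size of this step is not known from the data. The expectation is that compound 3 falls close to compound 1, with the step of a 1.3-fold higher number from compound 1 to compound 3 (0.11 log units; within the scatter) expected to be small and not clearly beyond the scatter in either direction. Compound 3 is therefore expected to give about 30000 nM, within a range from 8000 nM to 100000 nM.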

Compound 3, half-maximal inhibitory concentration: 79600 nM
Beside the measured number, compound 3's estimate is 2.7-fold (0.42 log units) below it; the measured number falls inside the stated range.
By their numbers in this assay, from the lowest: compound 2; then compound 1; then compound 3.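

In this assay, the series now has its first single-place step: hydrogen in place of acetyl on an oxygen on a saturated carbon gives a 3.4-fold higher number from compound 1 to compound 3 (0.53 log units; beyond the scatter). The earlier pair differed at several places at once and could not show this, whereas this step shows that the number responds to the acetoxy to hydroxy change at this position, and that the acetoxy form, compound 1, carries the lower number of the two. This rests on one pair only, so it is a reading of this position in this core and not a rule for the series, and nothing available bears on why the step has this direction or size.

The compounds shown leave open whether another group on this oxygen, such as a longer acyl chain like butanoyl, a benzoyl or a methyl ether, would give a number lower than that of compound 1 or one closer to that of compound 3. They also leave open whether the same acetoxy to hydroxy change at the remaining acetoxy group of the shared core would give a step of similar size.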